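Adding a Chloro Group and the Paw Edema Inhibition Number

The compounds below may be only part of what the source reports. "The series", "measured", "known", "first", "only" and "open" are said of these compounds alone.

Two compounds sharing one core have been examined in a functional assay on the whole organism (strain albino) for inhibition, with Rattus norvegicus as the target, read by paw edema, with stated times of 1 h and 2 h, at a dose of 100 mg/kg by the oral route; a higher number here means more inhibition at the dose given (going by the name of the read-out), a lower number less inhibition. Compound 1 `N#Cc1c(Cl)nc(SCC(=O)Nn2c(COc3ccc(Cl)cc3Cl)nc3ccccc3c2=O)nc1-c1ccc(Cl)cc1` gives 68.4% in this assay. Compound 2 `N#Cc1c(Nc2ccccc2)nc(SCC(=O)Nn2c(COc3ccc(Cl)cc3Cl)nc3ccccc3c2=O)nc1-c1ccccc1` gives 78.1% in this assay, the higher of the two numbers shown, though compound 1 lies only slightly lower and within the scatter, so the pair cannot be ordered. Among the measured compounds shown here, compound 1 and compound 2 differ in two places, and no single step between them is recorded.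

Compound 3 `N#Cc1c(Nc2ccccc2)nc(SCC(=O)Nn2c(COc3ccc(Cl)cc3Cl)nc3ccccc3c2=O)nc1-c1ccc(Cl)cc1` departs from compound 2 by one change: chloro in place of hydrogen on an aromatic carbon. Compound 1 carries the same 4-chlorophenyl group and gives 68.4%, so the change is expected to move the number little. The expected step of a number 4.1 percentage points lower from compound 2 to compound 3 (within the scatter) is small and not beyond the scatter, with no clear direction. Compound 3 is accordingly estimated at 74% in this assay, within a range from 61% to 85%.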

Compound 3, a percentage reported as inhibition, in the whole organism at one dose (the size of the read-out at that dose, not a potency): 50.9%
Compound 3: the middle estimate sits 23.1 percentage points above what was measured; measured number below the stated range.
By their numbers in this assay, from the lowest: compound 3; then compounds 1 and 2 (each within the scatter of the next).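

In this assay the change from phenyl to 4-chlorophenyl is not a silent one: chloro in place of hydrogen, para to a large group, brings a number 27.2 percentage points lower from compound 2 to compound 3 (beyond the scatter) and so takes the number beyond the scatter. With the 4-chlorophenyl group held in place, anilino in place of chloro brings a number 17.5 percentage points lower from compound 1 to compound 3 (beyond the scatter) as well, so in this setting the anilino group goes with the lower number. Nothing shown accounts for either step.

The compounds shown leave open whether a fluoro, methyl or methoxy group at the same place on the phenyl ring would bring a similar step. They also leave open whether the chloro step would recur in a compound carrying chloro instead of anilino, with plain phenyl in place of 4-chlorophenyl.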